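Swapping the Amide Cap: From Compound 3 to Compound 4

The source may hold more compounds than are shown below. What is called first, only, known or untested is meant among the compounds shown, and "the series" means these compounds.

Of the compounds shown here, three sharing one core have been measured in an assay on THP-1 cells for displacement of a labelled ligand from C-C chemokine receptor type 1 (Homo sapiens); on this read-out higher numbers stand for weaker inhibition and lower numbers for stronger inhibition. Compound 3 `Cc1ccccc1C(=O)N[C@@H](C(=O)N1CCC(c2ccc(Cl)cc2)CC1)C(C)C` gives 32 nM in this assay, the second highest of the three numbers. Its nearest neighbour is compound 2 `Cc1ccccc1CCC(=O)N[C@@H](C(=O)N1CCC(c2ccc(Cl)cc2)CC1)C(C)C`, which gives 19 nM; the step of a 1.7-fold higher number from compound 2 to compound 3 (0.23 log units; within the scatter) lies within the scatter, so the two cannot be ranked. Furthest away is compound 1 `Cc1ccc(CCC(=O)N[C@@H](C(=O)N2CCC(c3ccc(Cl)cc3)CC2)C(C)C)cc1`, which gives 105 nM, and here a 3.3-fold lower number from compound 1 to compound 3 (0.52 log units; beyond the scatter).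

Compound 4 `CC(C)[C@@H](NC(=O)CCc1ccc(F)cc1)C(=O)N1CCC(c2ccc(Cl)cc2)CC1` has not yet been measured. It differs from compound 3 in one place: 2-(4-fluorophenyl)ethyl in place of 2-methylphenyl on a carbonyl carbon. Going by the values given here, two measured steps bear on this change. The move a 3.3-fold lower number from compound 1 to compound 3 (0.52 log units; beyond the scatter) is essentially the reverse of the change in hand, apart from the fluorine, and the move a 5.5-fold lower number from compound 1 to compound 2 (0.74 log units; beyond the scatter) shows that where the methyl sits on a phenylethyl chain matters by a modest amount. Among the compounds with values here, no fluorine-bearing compound has been measured, so the part of the change that exchanges methyl for fluorine has no precedent here.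

Taken together, a modest rise in the number is expected, roughly undoing the step from compound 1 to compound 3. The expected step is a 2.5-fold higher number from compound 3 to compound 4 (0.40 log units; beyond the scatter). For compound 4 the estimate in this assay is 80 nM, with a range from 30 nM to 220 nM.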

Compound 4, half-maximal inhibitory concentration: 70 nM
The estimate for compound 4 lay 1.1-fold (0.06 log units) above the measured number; the measured number falls inside the stated range.
By their numbers in this assay, from the lowest: compounds 2 and 3 (each within the scatter of the next); then compounds 4 and 1 (each within the scatter of the next).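

In this assay the 2-(4-fluorophenyl)ethyl group on the carbonyl carbon does worse than the 2-methylphenyl group it replaces, with a 2.2-fold higher number from compound 3 to compound 4 (0.34 log units; beyond the scatter) as the measure of that loss. On the chain itself, the result is a 3.7-fold higher number from compound 2 to compound 4 (0.57 log units; beyond the scatter) when 4-fluorophenyl takes the place of 2-methylphenyl, while a 1.5-fold lower number from compound 1 to compound 4 (0.18 log units; within the scatter) stays within the scatter, so fluoro and methyl on this aromatic carbon cannot be told apart here. Among the three compounds with a ring on this chain, then, the 2-methylphenyl ring of compound 2 gives a lower number than either 4-substituted ring, and exchanging the 4-substituent, as far as these two small groups go, changes nothing that can be detected.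

On these data alone, it remains open whether a 2-fluorophenyl ring on the same chain would match compound 2, whether a 4-fluorophenyl ring placed directly on the carbonyl carbon would match compound 3, and how an amine or a carboxylic acid on the ring would fare. Nothing available here explains why these steps have the sizes they do.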